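A Nitro Group Added to Compound 3

This account rests on a few compounds, and the source may have more. Where it says the series, first, only, none or still open, it means among the compounds named here.

Values in a functional assay on SF-268 cells (Homo sapiens) for cytotoxicity, read by MTT assay, with a stated time of 3 days (on this read-out higher numbers stand for weaker inhibition and lower numbers for stronger inhibition), for the compounds measured so far
Compound 1 `N#Cc1c(Nc2ccccn2)nc(SCc2nc3ccccc3[nH]2)nc1-c1ccccc1` gives 6.75 nM
Compound 2 `N#Cc1c(-c2ccccc2)nc(SCc2nc3ccccc3[nH]2)nc1N1CCNCC1` gives 20000 nM
Compound 3 `N#Cc1c(-c2ccccc2)nc(SCc2nc3ccccc3[nH]2)nc1N1CCN(S(=O)(=O)c2ccccc2)CC1` gives 2.87 nM

Of these three numbers, compound 3 has the lowest, with compound 1 nearest to it and compound 2 far away. The next compound to be tested is compound 4 `N#Cc1c(-c2ccccc2)nc(SCc2nc3ccccc3[nH]2)nc1N1CCN(S(=O)(=O)c2ccccc2[N+](=O)[O-])CC1` which turns the phenylsulfonyl group of compound 3 into (2-nitrophenyl)sulfonyl. The change is nitro in place of hydrogen on an aromatic carbon and it puts nitro in place of hydrogen on an aromatic carbon, ortho to a large group.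

Among the measured compounds shown here, two measured steps bear on this. Putting piperazin-1-yl in place of (pyridin-2-yl)amino gave a 3000-fold higher number from compound 1 to compound 2 (3.47 log units; beyond the scatter) and adding phenylsulfonyl to the amine nitrogen in the ring then gave a 7000-fold lower number from compound 2 to compound 3 (3.84 log units; beyond the scatter) and both are large. Each of them swapped or added a whole group, however, and compound 4 keeps the phenylsulfonyl frame. For the measured compounds named here, no measured compound carries a substituent on that phenyl, so the data give no direct guide, and a much smaller move seems likely. In this assay the expected result is a 1.7-fold higher number from compound 3 to compound 4 (0.24 log units; within the scatter) with no step beyond the scatter foreseen in either direction. For compound 4 the estimated value is 5 nM (range 0.8 nM to 40 nM).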

Compound 4, half-maximal inhibitory concentration: 3 nM
Beside the measured number, compound 4's estimate is 1.7-fold (0.22 log units) above it; the measured number falls inside the stated range.
By their numbers in this assay, from the lowest: compounds 3 and 4 (each within the scatter of the next); then compound 1; then compound 2.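

In this assay, nitro in place of hydrogen on an aromatic carbon of the phenylsulfonyl group, ortho to a large group, gives a step that lies within the usual scatter (a 1.0-fold higher number from compound 3 to compound 4 (0.02 log units; within the scatter)), so this position accepts a nitro group with no change that can be told from noise. Compound 4 is also the first compound shown with a substituent on that phenyl, and adding the whole (2-nitrophenyl)sulfonyl group to the amine nitrogen in the ring still gives a large step (a 6700-fold lower number from compound 2 to compound 4 (3.82 log units; beyond the scatter)), of the same order as the one seen with the plain phenylsulfonyl group (a 7000-fold lower number from compound 2 to compound 3 (3.84 log units; beyond the scatter)). No measurement shown gives a reason for this tolerance of the nitro group.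

Going by these compounds, whether an amine or a carboxylic acid in place of the nitro would leave the number just as low remains open, and so does the effect of a nitro group on the other carbons of that ring. Also open, on these data alone, is whether a benzoyl group, with a carbonyl in place of the sulfonyl, would do on the amine nitrogen what the phenylsulfonyl group does.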